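From phenoxy to (4-fluorophenyl)sulfanyl on a shared core

The compounds below may be only part of what the source reports. "The series", "measured", "known", "first", "only" and "open" are said of these compounds alone.

Of the compounds shown here, three have numbers so far. In a functional assay on MCF7 cells (Homo sapiens) for antiproliferative activity, read by sulforhodamine B assay, with a stated time of 3 days (a lower number here means a stronger inhibitor, a higher number a weaker inhibitor), compound 1 (`c1ccc(Sc2ncnc3[nH]cnc23)cc1`) gives 31000 nM after the full treatment period. Compound 2 (`Fc1ccc(Sc2ncnc3c2ncn3C2COc3ccccc3CO2)cc1`) gives 11200 nM and compound 3 (`c1ccc(Oc2ncnc3ncn(C4COc5ccccc5CO4)c23)cc1`) gives 21100 nM in this assay as well. Compound 3 lies within the usual scatter of both other compounds, so these numbers do not separate it from either one.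

Compound 4 (`Fc1ccc(Sc2ncnc3ncn(C4COc5ccccc5CO4)c23)cc1`) differs from compound 3 in one place, with (4-fluorophenyl)sulfanyl in place of phenoxy on an aromatic carbon. Among the measured compounds shown here, no measured pair shows this swap on its own, so any expectation here is loose. Among the measured compounds, only compound 2 carries (4-fluorophenyl)sulfanyl, and its 11200 nM is within the scatter of the number for compound 3. The change in this assay is therefore expected to be slight, with a lower number at most. The estimated step of a 1.6-fold lower number from compound 3 to compound 4 (0.21 log units; within the scatter) is expected to stay within the scatter. Compound 4 is expected in this assay at 13000 nM (estimated range 5500 nM to 30000 nM).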

Compound 4, half-maximal inhibitory concentration: 14100 nM
Estimate against measurement, compound 4: 1.1-fold (0.04 log units) below; the measured number falls inside the stated range.
By their numbers in this assay, from the lowest: compounds 2, 4, 3 and 1 (each within the scatter of the next, the first and the last beyond it).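

In this assay, among the compounds shown here, putting (4-fluorophenyl)sulfanyl in place of phenoxy on this aromatic carbon gives a 1.5-fold lower number from compound 3 to compound 4 (0.18 log units; within the scatter) and so provides the one direct comparison at this position, which the earlier compounds could not offer. Within this pair, the two groups cannot be told apart by their numbers, even though the swap alters both the atom linking the ring to the core and the ring itself. Nothing measured here offers an explanation for this result.

Because the linking atom and the fluorine change together, this pair cannot show what either change does alone, and plain phenylsulfanyl on the same core would be needed to separate them. Going by these compounds, it also remains open whether a different kind of group on this carbon, such as an amine or a carboxylic acid, would shift the number beyond the scatter.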